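The source may report more compounds than this note shows. Statements on the series, on what has been measured and on what is new or still open speak of the compounds shown alone.

Working notes on the series, step from compound 3 to compound 4.

Going by the values given here, the three compounds measured so far share one core and differ only in the chain on the aromatic nitrogen. Compound 1 `CCn1ccnc1/C=C/C(=O)/C=C/c1coc2ccccc2c1=O` in a functional assay on PC-3 cells (Homo sapiens) for cytotoxicity, read by WST assay, with a stated time of 3 days (a lower number here means a stronger inhibitor, a higher number a weaker inhibitor), gives 1800 nM. Compound 2 `CCCn1ccnc1/C=C/C(=O)/C=C/c1coc2ccccc2c1=O` in this assay gives 2400 nM. Compound 3 `CCCCn1ccnc1/C=C/C(=O)/C=C/c1coc2ccccc2c1=O` in this assay gives 2000 nM, which puts compound 3 second highest of the three numbers, nearest to compound 1 and furthest from compound 2; all three values sit within the scatter of one another. The steps between them are small: a 1.3-fold higher number from compound 1 to compound 2 (0.12 log units; within the scatter), a 1.1-fold higher number from compound 1 to compound 3 (0.05 log units; within the scatter) and a 1.2-fold lower number from compound 2 to compound 3 (0.08 log units; within the scatter). Lengthening the chain by one or two carbons, in either direction, has so far moved nothing beyond the scatter.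

Compound 4 `CC(C)n1ccnc1/C=C/C(=O)/C=C/c1coc2ccccc2c1=O` carries the next variation of the same chain: isopropyl in place of butyl on an aromatic nitrogen. Each of the three measured steps bears on this change, since each also alters only the carbon count or shape of that chain, and each was within the scatter. No step beyond the scatter is therefore expected in this assay. The step of no change at the digits printed from compound 3 to compound 4 (within the scatter) is the estimated outcome. Compound 4 is expected to give 2000 nM, with a range from 1000 nM to 4000 nM.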

Compound 4, half-maximal inhibitory concentration: 2300 nM
Compound 4: the middle estimate sits 1.2-fold (0.06 log units) below what was measured; low and high end bracket the measured number.
By their numbers in this assay, from the lowest: compounds 1, 3, 4 and 2 (each within the scatter of the next).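

The isopropyl group brings branching to the chain carbon bound to the aromatic nitrogen, and in this assay this shape stays within the scatter of the straight chains, with a 1.2-fold higher number from compound 3 to compound 4 (0.06 log units; within the scatter) and a 1.3-fold higher number from compound 1 to compound 4 (0.11 log units; within the scatter). The exchange of propyl for isopropyl changes only the shape of the chain, and it gives a 1.0-fold lower number from compound 2 to compound 4 (0.02 log units; within the scatter), so at this position the read-out so far separates neither chain length nor branching from the scatter. Methyl in place of hydrogen also stays within the scatter, whether it stands three bonds along the chain from an aromatic nitrogen or on the chain carbon bound to that nitrogen: the same change on two cores in this assay, a 1.2-fold lower number (0.08 log units; within the scatter) from compound 2 to compound 3 and a 1.3-fold higher number (0.11 log units; within the scatter) from compound 1 to compound 4, 1.5-fold (0.19 log units) apart, within the scatter of two such steps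

All four compounds carry small saturated chains on this nitrogen, so the flat reading holds only for ethyl, propyl, butyl and isopropyl. Going by these compounds, whether it extends to a much longer chain, a benzyl group, or a chain ending in an amine or a carboxylic acid stays open, as does whether any group here can move the number beyond the scatter.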